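The compounds below may be only part of what the source reports. "The series", "measured", "known", "first", "only" and "open" are said of these compounds alone.

Three compounds have been measured in a functional assay on BT-549 cells (Homo sapiens) for inhibition, read by sulforhodamine B assay, with a stated time of 48 h; on this read-out lower numbers stand for stronger inhibition of growth and higher numbers for weaker inhibition of growth:
compound 1 `COc1ccc(C(=O)/C=C/c2cc(-c3cc(OC)c(OC)c(OC)c3)n[nH]2)cc1OC` gives 2900 nM
compound 2 `COc1ccc(C(=O)/C=C/c2cc(-c3cc(OC)c(OC)c(OC)c3)n[nH]2)cc1` gives 3860 nM
compound 3 `COc1cc(-c2cc(/C=C/C(=O)c3ccc(F)c(F)c3)[nH]n2)cc(OC)c1OC` gives 19300 nM

Compound 1 has the lowest number of the three. Its nearest neighbour is compound 2, with a 1.3-fold higher number from compound 1 to compound 2 (0.12 log units; within the scatter), a gap within the scatter, so the two cannot be told apart. Compound 3 lies furthest away, with a 6.7-fold higher number from compound 1 to compound 3 (0.82 log units; beyond the scatter).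

Compound 4 `COc1cc(C(=O)/C=C/c2cc(-c3cc(OC)c(OC)c(OC)c3)n[nH]2)cc(OC)c1OC` differs from compound 1 in one place: methoxy in place of hydrogen on an aromatic carbon. Two kinds of measured step bear on this. The step of a 1.3-fold higher number from compound 1 to compound 2 (0.12 log units; within the scatter) removes a methoxy group from the same ring and stays within the scatter, which suggests that one methoxy group more or less on that ring changes little. By contrast, a 6.7-fold higher number from compound 1 to compound 3 (0.82 log units; beyond the scatter) and a 5.0-fold higher number from compound 2 to compound 3 (0.70 log units; beyond the scatter) exchange the methoxy-bearing ring for a 3,4-difluorophenyl ring, and both give modest losses, so the compounds with methoxy groups on this ring show the lower numbers. Adding a further methoxy group is therefore expected to give a step no larger than the scatter, with at most a slight lean toward a lower number. For compound 4 the expected step is a 1.3-fold lower number from compound 1 to compound 4 (0.12 log units; within the scatter). Compound 4 is thus estimated at 2200 nM, with a range from 800 nM to 6500 nM.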

Compound 4, concentration for total growth inhibition: 2960 nM
Compound 4: the middle estimate sits 1.3-fold (0.13 log units) below what was measured; low and high end bracket the measured number.
By their numbers in this assay, from the lowest: compounds 1, 4 and 2 (each within the scatter of the next); then compound 3.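

Among these compounds, until now the only methoxy step on this ring was a removal, a 1.3-fold higher number from compound 1 to compound 2 (0.12 log units; within the scatter) in this assay. Compound 4 supplies the opposite test, with a methoxy group entering on an aromatic carbon ortho to a methoxy group and meta to a large group, and the result is a 1.0-fold higher number from compound 1 to compound 4 (0.01 log units; within the scatter) on the same read-out, so compound 1 and compound 4 cannot be told apart and this position accepts the extra group without a measurable penalty. Nothing shown here offers an explanation for this result.

On these data alone, what remains open is whether this tolerance is specific to methoxy or extends to quite different groups at the same position, such as a hydroxyl group, an amine, a carboxylic acid or a longer chain like butoxy. The only clear loss so far comes with the 3,4-difluorophenyl ring of compound 3, where a 6.7-fold higher number from compound 1 to compound 3 (0.82 log units; beyond the scatter) involves the whole ring, so these compounds cannot show which of its two fluorine atoms or which missing methoxy group matters.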